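The compounds below may be only part of what the source reports. "The series", "measured", "known", "first", "only" and "open" are said of these compounds alone.

Among the compounds with values here, in a functional assay on HepG2 cells (Homo sapiens) for inhibition, read by CCK-8 assay, with a stated time of 48 h (on this read-out higher numbers stand for weaker inhibition and lower numbers for stronger inhibition), compound 2 `Brc1ccc(C2=NN(C3=NC(c4ccccc4)CS3)C(c3ccc4ccccc4c3)C2)cc1` gives 20300 nM, the highest of the two numbers so far, with compound 1 `c1ccc(C2=NN(C3=NC(c4ccccc4)CS3)C(c3ccc4ccccc4c3)C2)cc1` nearest at 17200 nM. Within the data shown here, the only step known is a 1.2-fold higher number from compound 1 to compound 2 (0.07 log units; within the scatter), a change that stays within the scatter. Compound 3 `Clc1ccc(C2=NN(C3=NC(c4ccccc4)CS3)C(c3ccc4ccccc4c3)C2)cc1` differs from compound 2 by chloro in place of bromo on an aromatic carbon. Among the measured compounds shown here, the bromo-for-hydrogen step gives the only guide, and it did not move the number beyond the scatter, so compound 3 is expected to give 19000 nM, within 9000 nM to 40000 nM. The expected step is a 1.1-fold lower number from compound 2 to compound 3 (0.03 log units; within the scatter), likely inside the scatter.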

Compound 3, half-maximal inhibitory concentration: 22100 nM
For compound 3 the middle estimate is 1.2-fold (0.07 log units) below the measured one, within the range that was stated.
By their numbers in this assay, from the lowest: compounds 1, 2 and 3 (each within the scatter of the next).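

In this assay, chloro in place of bromo gives a 1.1-fold higher number from compound 2 to compound 3 (0.04 log units; within the scatter) and chloro in place of hydrogen gives a 1.3-fold higher number from compound 1 to compound 3 (0.11 log units; within the scatter) at this place, para to a large group. Chloro therefore joins bromo as a second group there that leaves the number within the scatter of compound 1. No evidence on why bears on this result. On these data alone, whether an amine or a carboxylic acid at this place would move the number beyond the scatter stays open. So does the effect of a change anywhere else on the shared core.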